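A few compounds are considered here, and "the series" means these few. Any claim that something is new, unique, unknown or untested is made for them only; others in the source may bear on it.

Measured compounds in the series so far:

Compound 1 `CCN(CC)CCCNCc1cn(-c2ccc(F)cc2F)nc1-c1ccccc1C` is reported in an ADME assay on Huh-7 cells (Homo sapiens) for cytotoxicity (on this read-out higher numbers stand for lower toxicity in this test and lower numbers for higher toxicity in this test), only as the assay limit > 20000 nM. Compound 2 `COc1ccc(-c2nn(-c3ccc(F)cc3F)cc2CNCCN2CCN(C)CC2)cc1` likewise reaches only the limit > 20000 nM in this assay.

Within the data shown here, compound 1 therefore has no number of its own in this assay, only a limit, and the one further value shown is also a limit; both sit at the limit of > 20000 nM in this assay, at which 2 of the 2 values shown sit. Among the measured compounds shown here, no step between measured compounds is available, as compound 1 and compound 2 differ in more than one place.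

Compound 3 `Cc1ccccc1-c1nn(-c2ccc(F)cc2F)cc1CNCc1ccncc1` is the next compound awaiting measurement. It differs from compound 1 by pyridin-4-yl in place of 2-(diethylamino)ethyl on a saturated chain carbon bound to an amine nitrogen.

With both measured values resting at the limit, no step beyond the scatter in this assay is expected in either direction. For compound 3 the expected outcome in this assay is 25000 nM, within 10000 nM to 60000 nM, meaning an expected step that the limit leaves unreadable from compound 1 to compound 3 and most likely another limit rather than a number.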

Compound 3, half-maximal cytotoxic concentration: > 20000 nM
Compound 3 ended at the assay's limit; the forecaster's own chance of this, stated with the estimate: 75%; the middle value is on the limit's open side.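

No step can be read between compound 1 and compound 3 in this assay, since both values are limits: the limit of > 20000 nM in this assay, at which 3 of the 3 values shown sit.

The compounds shown leave open where any of them would give an actual number, and whether pyridin-4-yl in place of 2-(diethylamino)ethyl alters the read-out at all.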